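This account rests on a few compounds, and the source may have more. Where it says the series, first, only, none or still open, it means among the compounds named here.

Measured so far in a functional assay on CCRF-CEM cells (Homo sapiens) for antiproliferative activity, read by fluorescence and resazurin assay, with a stated time of 48 h; a higher number here means a weaker inhibitor, a lower number a stronger inhibitor:
Compound 1 `O=C(N/N=C/c1cc2ccccc2nc1Cl)c1cc2cc(Br)ccc2oc1=O` gives 7450 nM.
Compound 2 `Cc1noc(NS(=O)(=O)c2ccc(NC(=O)c3cc4cc([N+](=O)[O-])ccc4oc3=O)cc2)c1C` gives 14300 nM.
Compound 3 `Cc1noc(NS(=O)(=O)c2ccc(NC(=O)c3cc4cc(Br)ccc4oc3=O)cc2)c1C` gives 14600 nM.

Compound 4 `O=C(N/N=C/c1cc2ccccc2nc1Cl)c1cc2cc([N+](=O)[O-])ccc2oc1=O` has not yet been measured in this assay. It arises from compound 1 by a single change, (nitro in place of bromo on an aromatic carbon). The same change, (nitro in place of bromo on an aromatic carbon), occurs on a different core from compound 3 to compound 2, where it gave a 1.0-fold lower number from compound 3 to compound 2 (0.01 log units; within the scatter). The difference between the two cores is not broken down here. The values of compound 1 and compound 3 lie within the usual scatter of each other, as do those of compound 1 and compound 2. Among the compounds with values here, because the one measured instance of this change gave a 1.0-fold lower number from compound 3 to compound 2 (0.01 log units; within the scatter), an equally small step is expected for compound 4: a 1.0-fold higher number from compound 1 to compound 4 (0.00 log units; within the scatter). Compound 4 is therefore estimated at 7500 nM, expected to fall between 3500 nM and 16000 nM.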

Compound 4, half-maximal inhibitory concentration: 26000 nM
Compound 4: the middle estimate sits 3.5-fold (0.54 log units) below what was measured; measured number outside the range, above it.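

Nitro in place of bromo does not give the same result on the two cores in this assay: the same change on two cores in this assay, a 1.0-fold lower number (0.01 log units; within the scatter) from compound 3 to compound 2 and a 3.5-fold higher number (0.54 log units; beyond the scatter) from compound 1 to compound 4, 3.6-fold (0.55 log units) apart, beyond the scatter of two such steps One core shows no real change, while the other gives a 3.5-fold higher number from compound 1 to compound 4 (0.54 log units; beyond the scatter), so in this series a step measured on one core is a poor guide to the step on another. With only one pair per core, this does not show why the cores differ, or whether the gap would hold for other pairs of groups.

The compounds shown leave open how an amine or a methoxy group on the same aromatic carbon would behave on each core. As far as these compounds go, whether such groups would also separate the two cores remains unknown.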